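The source may report more compounds than this note shows. Statements on the series, on what has been measured and on what is new or still open speak of the compounds shown alone.

Measured in an ADME assay on HepG2 cells (Homo sapiens) for inhibition, with a stated time of 48 h; a lower number here means that less compound is needed, a higher number that more compound is needed for the effect:
- Compound 1 `CC(C(=O)N1C[C@H]2CCC[C@H]2C1)N1CCN(S(=O)(=O)c2ccc(C(C)(C)C)cc2)CC1`: > 40000 nM
- Compound 2 `CC(C(=O)N1CCN(C)CC1)N1CCN(S(=O)(=O)c2ccc(C(C)(C)C)cc2)CC1`: > 40000 nM

Neither entry is a true number, since each is a limit of the assay. Compound 2 therefore has no exact position, and it shares its standing with compound 1: the limit of > 40000 nM in this assay, at which 2 of the 2 values shown sit.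

Compound 3 `CC(C(=O)N(C)Cc1ccccc1)N1CCN(S(=O)(=O)c2ccc(C(C)(C)C)cc2)CC1` keeps the shared core and changes one group: benzyl(methyl)amino in place of 4-methylpiperazin-1-yl on a carbonyl carbon. Benzyl(methyl)amino stands in place of 4-methylpiperazin-1-yl on a carbonyl carbon.

Going by the values given here, one measured step bears on this change, because it also swaps the group on a carbonyl carbon: a step that the two limits leave unreadable from compound 1 to compound 2. That step has no readable size, so it offers no measured effect to carry over to compound 3.

Compound 2 gives > 40000 nM, a limit, so no step beyond the scatter is expected in this assay. The expected step is a number no higher from compound 2 to compound 3 (the limit leaves the size open). The data cannot exclude a real number for the new group, so the range is kept wide. For compound 3 the estimate is 40000 nM, with an expected range of 15000 nM to 60000 nM.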

Compound 3, half-maximal effective concentration: > 40000 nM
Compound 3: no number, only a limit (the forecaster's own chance of this, stated with the estimate: 75%); the middle value sits exactly at the limit.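

Compound 3 ends at a limit of the assay, not at a number, just as compound 1 and compound 2 do, so no step among these three compounds can be read: the limit of > 40000 nM in this assay, at which 3 of the 3 values shown sit.

Left open is whether the different groups on the carbonyl carbon differ at all in this assay, and how much of any of these compounds the effect would take.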